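Lengthening the amide chain from compound 3 to compound 4

This account rests on a few compounds, and the source may have more. Where it says the series, first, only, none or still open, it means among the compounds named here.

Three measured compounds share one core and differ only in the chain attached to the amide carbonyl. In a functional assay on SW1573 cells (Homo sapiens) for cytotoxicity, read by sulforhodamine B assay, with a stated time of 72 h (on this read-out higher numbers stand for weaker inhibition and lower numbers for stronger inhibition), compound 1 `CC(=O)Nc1ccn([C@@H]2CO[C@H](CO)O2)c(=O)n1` gives 10700 nM. Compound 2 `CCCCC(=O)Nc1ccn([C@@H]2CO[C@H](CO)O2)c(=O)n1` gives 9130 nM in this assay, and compound 3 `CCCCCCCCCC(=O)Nc1ccn([C@@H]2CO[C@H](CO)O2)c(=O)n1` gives 40 nM. Compound 3 stands lowest of the three, and its gaps to both other compounds lie beyond the scatter. The measured steps show how the chain length bears on the read-out: a 1.2-fold lower number from compound 1 to compound 2 (0.07 log units; within the scatter), whereas a 270-fold lower number from compound 1 to compound 3 (2.43 log units; beyond the scatter) and a 230-fold lower number from compound 2 to compound 3 (2.36 log units; beyond the scatter).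

Compound 4 `CCCCCCCCCCCCCCCCCC(=O)Nc1ccn([C@@H]2CO[C@H](CO)O2)c(=O)n1` carries the change (octyl in place of hydrogen on a saturated chain carbon, nine bonds along the chain from a carbonyl carbon). For the measured compounds named here, no measured step covers a chain this long. The two large steps both end at compound 3 and both point downward in this assay, but the first lengthening, between compound 1 and compound 2, brought nothing beyond the scatter, so the data do not show whether the downward trend continues, flattens or turns. The account therefore expects for compound 4 a step of modest size, a 2.0-fold higher number from compound 3 to compound 4 (0.30 log units; within the scatter), with no confident direction. The estimate for compound 4 in this assay is 80 nM, expected to fall between 10 nM and 600 nM.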

Compound 4, half-maximal inhibitory concentration: 125 nM
Beside the measured number, compound 4's estimate is 1.6-fold (0.19 log units) below it, within the range that was stated.
By their numbers in this assay, from the lowest: compound 3; then compound 4; then compounds 2 and 1 (each within the scatter of the next).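

In this assay, for the compounds shown here, octyl in place of hydrogen on a saturated chain carbon, nine bonds along the chain from a carbonyl carbon, gives a 3.1-fold higher number from compound 3 to compound 4 (0.49 log units; beyond the scatter), the first step in this set that goes upward beyond the scatter, so lengthening the chain does not keep lowering the number past compound 3. The added octyl does not undo the earlier gain, since compound 4 at 125 nM still stands far below compound 2 at 9130 nM, and among these four chains the lowest number belongs to the chain of compound 3 rather than the longest one. Nothing available explains why the number falls so sharply and then rises again with chain length.

These four compounds leave open how the number behaves at chain lengths in the wide gaps between them, including whether butyl in place of hydrogen at this same carbon would give a number under that of compound 3, and whether a still longer chain would raise the number further. They also leave open what an amine or a carboxylic acid would do in place of the octyl at this carbon.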